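This account rests on a few compounds, and the source may have more. Where it says the series, first, only, none or still open, it means among the compounds named here.

Among the measured compounds shown here, compound 2 `CSc1nsnc1C1CN2CCC[C@H]1C2` holds the only actual number among the two measured compounds in a functional assay on the whole organism for inhibition, with Mus musculus as the target; a higher number here means that more compound is needed for the effect, a lower number that less compound is needed: compound 2 gives 0.2 mg/kg. Compound 1 `CCCCSc1nsnc1[C@H]1CN2CCC[C@H]1C2` does not give a number, only the assay's limit of > 1 mg/kg (the limit of > 1 mg/kg in this assay, at which 1 of the 2 values shown sits). Compound 3 `CCCCCSc1nsnc1C1CN2CCC[C@H]1C2` is not yet measured; it differs from compound 2 by butyl in place of hydrogen on a saturated chain carbon bound to a sulfur. For the measured compounds named here, no measured step of this kind exists. Compound 1, with its longer chain on the sulfur, gives only the limit of > 1 mg/kg, which points toward weakening. The step from compound 2 to compound 3 is therefore expected to be a 10-fold higher number from compound 2 to compound 3 (1.00 log units; beyond the scatter). Compound 3 is estimated at 2 mg/kg, plausibly between 0.4 mg/kg and 10 mg/kg, with a real chance of only a limit.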

Compound 3, dose for half-maximal effect: 0.054 mg/kg
Compound 3: the middle estimate sits 37-fold (1.57 log units) above what was measured, outside the stated range (below it).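

With butyl in place of hydrogen on the saturated chain carbon bound to the sulfur, this assay shows a 3.7-fold lower number from compound 2 to compound 3 (0.57 log units; beyond the scatter). Among the compounds shown here, this is the first measured step at this position, and it shows that going from methylsulfanyl to pentylsulfanyl lowers the dose needed rather than raising it. Compound 1 gives only a limit, > 1 mg/kg, and differs from the other two compounds in more than one place, so it fixes no step: the limit of > 1 mg/kg in this assay, at which 1 of the 3 values shown sits.

Two chain lengths with actual numbers cannot show a trend. From the compounds shown here alone, whether a longer chain such as heptyl, or an amine at the chain end, would lower the number further remains open.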